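A few compounds are considered here, and "the series" means these few. Any claim that something is new, unique, unknown or untested is made for them only; others in the source may bear on it.

Going by the values given here, compound 1, `COc1cc(-c2cc(/C=C/C(=O)c3ccc(N)cc3)[nH]n2)cc(OC)c1OC`, is the only compound here with a number rather than a limit: in a functional assay on NCI/ADR-RES cells (Homo sapiens) for inhibition, read by sulforhodamine B assay, with a stated time of 48 h (on this read-out higher numbers stand for weaker inhibition of growth and lower numbers for stronger inhibition of growth), compound 1 gives 65800 nM. Compound 2, `COc1ccc(-c2cc(/C=C/C(=O)c3ccc(N)cc3)[nH]n2)cc1OC`, differs from it by hydrogen in place of methoxy on an aromatic carbon. In this assay compound 2 reaches only a limit, > 100000 nM, which is a floor of the assay and not a number. Among the compounds with values here, that step is an at least 1.5-fold higher number from compound 1 to compound 2 (0.18 log units; that floor lies within the scatter), and it is the only measured step; the limit is noted as the limit of > 100000 nM in this assay, at which 1 of the 2 values shown sits.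

Compound 3, `COc1cc(-c2cc(/C=C/C(=O)c3ccc(F)c(F)c3)[nH]n2)cc(OC)c1OC`, is built from compound 1 by 3,4-difluorophenyl in place of 4-aminophenyl on a carbonyl carbon. Within the data shown here, the one measured step changes a methoxy on an aromatic ring, not the ring on the carbonyl carbon, so it gives no direct guide to this change. With so little to rest on, compound 3 is expected to stay close to compound 1, a step of a 1.3-fold lower number from compound 1 to compound 3 (0.12 log units; within the scatter). Compound 3 is therefore estimated at 50000 nM, within 10000 nM to 200000 nM.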

Compound 3, concentration for total growth inhibition: 50500 nM
Compound 3: the middle estimate sits 1.0-fold (0.00 log units) below what was measured; low and high end bracket the measured number.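

Putting 3,4-difluorophenyl in place of 4-aminophenyl on the carbonyl carbon gives a 1.3-fold lower number from compound 1 to compound 3 (0.11 log units; within the scatter) in this assay, so on this read-out the two compounds cannot be told apart. The earlier step concerned only a methoxy on the other aromatic ring, whereas this one shows that the nitrogen of the 4-aminophenyl group is not required to keep the growth inhibition seen for compound 1, since a ring with two fluorines and no nitrogen does as well. Nothing shown here gives a cause for this lack of change.

As far as these compounds go, it remains open whether a carboxylic acid or a nitrile on this ring would move the number beyond the scatter. Also open, from the compounds shown here alone, is whether 3,4-difluorophenyl would behave the same way on the core of compound 2.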